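Hydroxy to Fluoro on a Well-Tolerated Side Chain

The source may hold more compounds than are shown below. What is called first, only, known or untested is meant among the compounds shown, and "the series" means these compounds.

Compound 3 `O=c1n(Cc2cc3cc(Cl)ccc3n2CCCCO)c2cnccc2n1C1CC1` was tested in an ADME assay on HeLa cells (Homo sapiens) for cytotoxicity, read by ATP content, with a stated time of 3 days; a higher number here means that more compound is tolerated, a lower number that less compound is tolerated. Compound 3 reaches only the limit of > 50000 nM, so no number is known for it. Two relatives share its core and differ only on the same chain. Compound 1 `CS(=O)(=O)CCCn1c(Cn2c(=O)n(C3CC3)c3ccncc32)cc2cc(Cl)ccc21` likewise gives only the limit > 50000 nM. Compound 2 `N=C(CCCn1c(Cn2c(=O)n(C3CC3)c3ccncc32)cc2cc(Cl)ccc21)NO` also stops at the limit > 50000 nM. The steps a step that the two limits leave unreadable from compound 1 to compound 3, a step that the two limits leave unreadable from compound 1 to compound 2 and a step that the two limits leave unreadable from compound 2 to compound 3 are therefore unreadable, as the limit of > 50000 nM in this assay, at which 3 of the 3 values shown sit, shows. Compound 4 `O=c1n(Cc2cc3cc(Cl)ccc3n2CCCCF)c2cnccc2n1C1CC1` differs from compound 3 by fluoro in place of hydroxy on a saturated chain carbon, four bonds along the chain from an aromatic nitrogen. With every measured change on this chain leaving the value at the limit, compound 4 is expected to stay there too, a step of a number no higher from compound 3 to compound 4 (the limit leaves the size open). Compound 4 is estimated at 50000 nM, within 20000 nM to 200000 nM.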

Compound 4, half-maximal cytotoxic concentration: > 50000 nM
Compound 4 was reported as a limit (the forecaster's own chance of this, stated with the estimate: 80%); the middle value sits exactly at the limit.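

Among these compounds, compound 4 stops at a limit, as do compound 1, compound 2 and compound 3, so no step among them can be read: the limit of > 50000 nM in this assay, at which 4 of the 4 values shown sit. The compounds shown leave open where each true value lies in this assay, and whether any change on this chain shifts it.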